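Pyridin-2-yl for 4-bromophenyl: notes on four analogues

A few compounds are considered here, and "the series" means these few. Any claim that something is new, unique, unknown or untested is made for them only; others in the source may bear on it.

Compound 1 `C=C1C[C@]23C[C@@]1(O)CC[C@H]2c1ccc(O)c(C)c1[C@@H]3Cn1cc(-c2ccccn2)nn1` carries pyridin-2-yl on the five-membered aromatic ring with 3 nitrogen. In a functional assay on HL-60 cells (Homo sapiens) for cytotoxicity, read by MTT assay, with a stated time of 4 days (on this read-out higher numbers stand for weaker inhibition and lower numbers for stronger inhibition), compound 1 gives > 20000 nM, which is a limit of the assay and not a number. Compound 2 `C=C1C[C@]23C[C@@]1(O)CC[C@H]2c1ccc(O)c(C)c1[C@@H]3Cn1cc(-c2ccc(Br)cc2)nn1` is its 4-bromophenyl counterpart on the same core. In this assay compound 2 gives > 20000 nM, again a limit of the assay. Compound 1 differs from compound 2 by pyridin-2-yl in place of 4-bromophenyl on an aromatic carbon. The step that the two limits leave unreadable from compound 2 to compound 1 cannot be read, since both values sit at the limit of > 20000 nM in this assay, at which 3 of the 3 values shown sit.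

Compound 3 `C=C1C[C@]23C[C@@]1(O)CC[C@@H]2c1cccc(C)c1[C@@H]3Cn1cc(-c2ccc(Br)cc2)nn1` carries the 4-bromophenyl group on a second core; the difference between the core of compound 3 and the core of compound 2 is not broken down here. In this assay compound 3 gives > 20000 nM, a limit of the assay. Compound 4 `C=C1C[C@]23C[C@@]1(O)CC[C@@H]2c1cccc(C)c1[C@@H]3Cn1cc(-c2ccccn2)nn1`, not yet measured, differs from compound 3 by pyridin-2-yl in place of 4-bromophenyl on an aromatic carbon, the same change as that from compound 2 to compound 1, at a place described in the same words.

For compound 4 the expected step is a step that the limit leaves unreadable from compound 3 to compound 4, which rests on the step that the two limits leave unreadable from compound 2 to compound 1 being unreadable and on compound 3 standing at the limit of > 20000 nM in this assay, at which 3 of the 3 values shown sit. Compound 4 is therefore expected to return a limit rather than a number in this assay, with an estimate of 30000 nM and a range from 15000 nM to 100000 nM.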

Compound 4, half-maximal inhibitory concentration: > 20000 nM
Compound 4 ended at the assay's limit; the forecaster's own chance of this, stated with the estimate: 85%; the middle value lies beyond the limit too.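

In this assay compound 4 gives > 20000 nM, a limit of the assay and not a number. No step can be read from compound 3 to compound 4, nor from compound 2 to compound 1, because every value sits at the same limit: the limit of > 20000 nM in this assay, at which 4 of the 4 values shown sit.

The compounds shown leave open whether pyridin-2-yl in place of 4-bromophenyl changes the read-out at all on either core.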